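Dropping a Methyl Group: Expected Effect on Cell Growth

The source may report more compounds than this note shows. Statements on the series, on what has been measured and on what is new or still open speak of the compounds shown alone.

Measured so far:
Compound 2 `Brc1ccc2nc(-c3ccco3)cc(-c3ccccc3)c2c1`: 631000 nM
Compound 3 `COc1cc(-c2cc(-c3ccccc3)c3cc(Br)ccc3n2)cc(OC)c1OC`: 105000 nM

Compound 1 `Cc1ccc(-c2cc(-c3ccccc3)c3cc(Br)ccc3n2)cc1` is reported in an ADME assay on CCD 19Lu cells (Homo sapiens) for antiproliferative activity, read by MTT assay, with a stated time of 24 h (a higher number here means a weaker inhibitor, a lower number a stronger inhibitor), only as "not determined" (no result reported), so it stands nowhere on these numbers; only compound 2 and compound 3 give values, and both are weak. Compound 4 `Brc1ccc2nc(-c3ccccc3)cc(-c3ccccc3)c2c1` differs from compound 1 in a single place (hydrogen in place of methyl on an aromatic carbon). Among the compounds with values here, no two measured compounds differ in only one place, so no measured step is available to guide this change. Compound 1 and compound 4 share the same core, and the change is small, so in this assay no step beyond the usual scatter is expected in either direction. Compound 4 is expected to give about 300000 nM, with a likely range from 80000 nM to 1000000 nM.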

Compound 4, half-maximal inhibitory concentration: 669000 nM
Compound 4: middle estimate off by 2.2-fold (0.35 log units), on the low side; the measured number falls inside the stated range.
By their numbers in this assay, from the lowest: compound 3; then compounds 2 and 4 (each within the scatter of the next).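

In this assay, the aromatic carbon of the shared core that carries furan-2-yl in compound 2 now has its first measured swap, phenyl for furan-2-yl (a 1.1-fold higher number from compound 2 to compound 4 (0.03 log units; within the scatter)), so these two rings cannot be told apart here. The step from 4-methylphenyl to phenyl cannot be read, since compound 1 has no number. No measured evidence bears on this result. Open still is how an amine or a carboxylic acid on that phenyl ring would read in this assay.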